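This account rests on a few compounds, and the source may have more. Where it says the series, first, only, none or still open, it means among the compounds named here.

Working notes on the series.

Compound 1 `CC1=NN(C(=O)c2ccc(C)cc2)C(c2cc(Br)cc(Br)c2O)C1` and compound 2 `Cc1ccc(S(=O)(=O)N2N=C(c3cc4ccccc4oc3=O)CC2c2ccccc2)cc1` share no single reported number: in a functional assay on HepG2 cells (Homo sapiens) for cytotoxicity, read by MTT assay, with a stated time of 48 h (a lower number here means a stronger inhibitor, a higher number a weaker inhibitor), compound 1 gives "not active" (no number reported), and compound 2 in this assay gives "not active" (no number reported). Among the measured compounds shown here, compound 3 `CCCNCC(=O)N1N=C(c2cc3ccccc3oc2=O)CC1c1ccccc1` is the only member of the set with a number: in this assay compound 3 gives 10800 nM, and so it stands alone as the sole measured point, with nothing to rank it against. For the measured compounds named here, no pair of measured compounds differing in one place is available, so no step size is known from the data themselves.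

Compound 4 `CCN(CC)C1CCN(CC(=O)N2N=C(c3cc4ccccc4oc3=O)CC2c2ccccc2)CC1` differs from compound 3 by 4-(diethylamino)piperidin-1-yl in place of propylamino on a saturated chain carbon bound to a carbonyl carbon. Nothing in the measured set tells how this replacement moves the read-out, so the expected step in this assay from compound 3 to compound 4 is taken as none beyond the usual scatter, that is a 1.2-fold lower number from compound 3 to compound 4 (0.08 log units; within the scatter). On that basis compound 4 is estimated at 9000 nM in this assay, within a range from 3000 nM to 30000 nM, with a real chance that no number is reported at all.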

Compound 4, half-maximal inhibitory concentration: 19300 nM
Compound 4: middle estimate off by 2.1-fold (0.33 log units), on the low side; measured number inside the range.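

On a saturated chain carbon bound to a carbonyl carbon, 4-(diethylamino)piperidin-1-yl in place of propylamino gives, in this assay, a 1.8-fold higher number from compound 3 to compound 4 (0.25 log units; within the scatter). Among the compounds shown here, this is the first step known at this position: a group of 11 heavy atoms with one six-membered non-aromatic ring and 0 hydrogen-bond donors replaces one of 4 heavy atoms with no ring and 1 hydrogen-bond donor, and the step stays within the scatter. No measured finding bears on this result, and the step stands without an explanation.

A single pair sets no trend for this position, and the size of the entering group cannot be separated from its ring or its donor count. On these data alone, it remains open whether a carboxylic acid, a morpholine or a longer alkyl chain on this carbon would stay within the scatter of these two compounds.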